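The source may hold more compounds than are shown below. What is called first, only, known or untested is meant among the compounds shown, and "the series" means these compounds.

Measured compounds:
- compound 1, `C=CCc1cc(-c2ccc(OC)cc2)cc(CC=C)c1O`: 75600 nM
- compound 2, `C=CCc1cc(-c2cccc(C(F)(F)F)c2)ccc1O`: 73000 nM

Of the compounds shown here, two have been tested in a functional assay on A549 cells (Homo sapiens) for antiproliferative activity, read by MTT assay, with a stated time of 24 h; on this read-out higher numbers stand for weaker inhibition and lower numbers for stronger inhibition. Compound 1 gives 75600 nM there, and compound 2 gives 73000 nM. The two numbers lie within the scatter of each other, so compound 1 cannot be set apart from compound 2 on these data; both sit at the same weak level. Going by the values given here, no pair of measured compounds differs in only one place, so no measured step is available.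

Compound 3, `C=CCc1cc(-c2ccc(OC)cc2)ccc1O`, is the next compound in line. It differs from compound 1 as follows: hydrogen in place of allyl on an aromatic carbon. Among the compounds with values here, there is no measured example of this change, so the expectation rests only on the weak level of compound 1. A step no larger than the scatter, in either direction, is expected in this assay for the change from compound 1 to compound 3, with a slight lean toward a higher number. Compound 3 is therefore estimated at 95000 nM, with an expected range from 35000 nM to 260000 nM, which corresponds to an expected step of a 1.3-fold higher number from compound 1 to compound 3 (0.10 log units; within the scatter).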

Compound 3, half-maximal inhibitory concentration: > 100000 nM
Compound 3: a limit, no number; the forecaster's own chance of this, stated with the estimate: 25%; at least 1.0-fold (0.02 log units) between middle value and limit.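

In this assay, the position ortho to a hydroxy group now has its first measured change, and compound 3 gives a limit rather than a number: the limit of > 100000 nM in this assay, at which 1 of the 3 values shown sits.

Read as a floor, the change gives an at least 1.3-fold higher number from compound 1 to compound 3 (0.12 log units; that floor lies within the scatter), so hydrogen in place of allyl on this aromatic carbon brings no stronger inhibition, while the true size of the step stays unknown. The data therefore do not show that this allyl group is needed for the weak inhibition of compound 1, only that losing it brings no gain.

From the compounds shown here alone, whether a longer chain, an amine or a carboxylic acid on this carbon would give stronger inhibition stays open. Going by these compounds, the effect of an amine in place of the hydroxy group also stays open.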